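A heterocycle swap on the amide nitrogen of compound 1

The source may report more compounds than this note shows. Statements on the series, on what has been measured and on what is new or still open speak of the compounds shown alone.

Among the compounds with values here, in a functional assay on MCF7 cells (Homo sapiens) for antiproliferative activity, with a stated time of 72 h (on this read-out lower numbers stand for an effect already at smaller amounts and higher numbers for an effect only at larger amounts of compound), compound 1 (`O=C1OCc2cc(N(Cc3ccc(C4CCCCC4)cn3)C(=O)[C@H]3CCN3S(=O)(=O)c3c(F)c(F)c(F)c(F)c3F)ccc21`) gives 4600 nM, which is the only plain number among the two values shown. Compound 2 (`O=C(NO)c1ccc(N(Cc2ccc(C3CCOCC3)cc2)C(=O)[C@H]2CCN2S(=O)(=O)c2c(F)c(F)c(F)c(F)c2F)cc1`) is reported at a limit of the assay, > 10000 nM, not as a number; it sits at the limit of > 10000 nM in this assay, at which 1 of the 2 values shown sits. Compound 3 (`O=C([C@H]1CCN1S(=O)(=O)c1c(F)c(F)c(F)c(F)c1F)N(Cc1ccc(C2CCCCC2)cn1)c1ccc2c(=O)[nH]cnc2c1`) differs from compound 1 at one site: a group of 11 heavy atoms (8 carbon, 2 nitrogen, 1 oxygen; one six-membered aromatic ring of carbon only, one six-membered aromatic ring with 2 hetero atoms) in place of a group of 10 heavy atoms (8 carbon, 2 oxygen; one five-membered non-aromatic ring with 1 hetero atom, one six-membered aromatic ring of carbon only), on an amide-type nitrogen. Within the data shown here, no pair of measured compounds differs in a single place, and the size of this kind of step has not been measured here. The author expects a modest gain for the new heterocycle, with the step in this assay estimated as a 1.8-fold lower number from compound 1 to compound 3 (0.26 log units; within the scatter), a change that would pass the scatter only at its larger end. For compound 3 in this assay the estimate is 2500 nM, expected to fall between 600 nM and 10000 nM.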

Compound 3, half-maximal effective concentration: 3600 nM
For compound 3 the middle estimate is 1.4-fold (0.16 log units) below the measured one, within the range that was stated.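

In this assay, within the data shown here, this is the first step that can be read at this position, on an amide-type nitrogen, and it comes to a 1.3-fold lower number from compound 1 to compound 3 (0.11 log units; within the scatter). The position therefore accepts the group with a six-membered aromatic ring with 2 hetero atoms and a hydrogen-bond donor in place of the group with a five-membered non-aromatic ring with 1 hetero atom, and the read-out stays within the scatter, so the two compounds cannot be told apart here. Nothing in the available evidence speaks to why this exchange leaves the read-out within the scatter.

From the compounds shown here alone, whether a smaller substituent on this nitrogen, such as one carrying an amine or a carboxylic acid, would move the number beyond the scatter remains open. The compounds shown also do not separate the hydrogen-bond donor from the change of ring.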